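Ester and acid analogues of a shared core against MCF7 cells

The source may report more compounds than this note shows. Statements on the series, on what has been measured and on what is new or still open speak of the compounds shown alone.

Measured compounds:
compound 1 `CCOC(=O)C(C)Oc1cc(O)c2c(=O)c(O)c(-c3ccc(OC)cc3)oc2c1CC=C(C)C` > 100000 nM
compound 2 `COc1ccc(-c2oc3c(CC=C(C)C)c(OC(C)C(=O)O)cc(O)c3c(=O)c2O)cc1` > 100000 nM
compound 3 `COc1ccc(-c2oc3c(CC=C(C)C)c(OCC(=O)O)cc(O)c3c(=O)c2O)cc1` > 100000 nM

The study tested three compounds in a functional assay on MCF7 cells (Homo sapiens) for cytotoxicity, read by MTT assay; a higher number here means a weaker inhibitor, a lower number a stronger inhibitor. Compound 1 `CCOC(=O)C(C)Oc1cc(O)c2c(=O)c(O)c(-c3ccc(OC)cc3)oc2c1CC=C(C)C` gave only a limit of the assay, > 100000 nM. Compound 2 `COc1ccc(-c2oc3c(CC=C(C)C)c(OC(C)C(=O)O)cc(O)c3c(=O)c2O)cc1` likewise gave a limit, > 100000 nM. Compound 3 `COc1ccc(-c2oc3c(CC=C(C)C)c(OCC(=O)O)cc(O)c3c(=O)c2O)cc1` also gave a limit, > 100000 nM. Because of the limit of > 100000 nM in this assay, at which 3 of the 3 values shown sit, none of the steps among them can be sized: a step that the two limits leave unreadable from compound 2 to compound 1, a step that the two limits leave unreadable from compound 1 to compound 3 and a step that the two limits leave unreadable from compound 2 to compound 3 all remain unreadable.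

Compound 4 `CCOC(=O)COc1cc(O)c2c(=O)c(O)c(-c3ccc(OC)cc3)oc2c1CC=C(C)C` is not yet measured. It differs from compound 3 by ethyl in place of hydrogen on an oxygen next to a carbonyl group. The same change was made from compound 2 to compound 1, (ethyl in place of hydrogen on an oxygen next to a carbonyl group), and the two places are described in the same words, so this is the same change. The cores of compound 3 and compound 2 differ by hydrogen in place of methyl on a saturated chain carbon bound to a carbonyl carbon and an oxygen on an aromatic ring.

Since the earlier step stayed within the limit, the step from compound 3 to compound 4 is expected to be a step that the limit leaves unreadable from compound 3 to compound 4. Compound 4 is therefore estimated at 150000 nM in this assay, between 50000 nM and 500000 nM.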

Compound 4, half-maximal inhibitory concentration: 27900 nM
Estimate against measurement, compound 4: 5.4-fold (0.73 log units) above; the whole stated range lies above it.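

In this assay, ethyl in place of hydrogen on an oxygen next to a carbonyl group gives an at least 3.5-fold lower number from compound 3 to compound 4 (0.55 log units; beyond the scatter), so on this core the change has a readable effect, though only as a bound. Compound 4 also differs from the other two compounds, with an at least 3.5-fold lower number from compound 2 to compound 4 (0.55 log units; beyond the scatter) and, for hydrogen in place of methyl on the saturated chain carbon, an at least 3.5-fold lower number from compound 1 to compound 4 (0.55 log units; beyond the scatter). The same ethyl change on the core of compound 2 cannot be sized, and no step among compound 1, compound 2 and compound 3 can be read, so the series does not show whether the change carries from one core to the other, or with what size, because all three rest on a single limit: the limit of > 100000 nM in this assay, at which 3 of the 4 values shown sit.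

On these data alone, it remains open whether a longer chain on the same oxygen, such as propyl or butyl, would go with a lower or higher number than ethyl. The compounds shown also leave open how an amide in place of the ester would read in this assay.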